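Fluorine Replaces Methyl on the Phenyl at the Ring Nitrogen

The source may report more compounds than this note shows. Statements on the series, on what has been measured and on what is new or still open speak of the compounds shown alone.

Compound 2 `Cc1cccc(-n2cc(CNC(=O)c3cccc4c3cnn4C(C)C)nn2)c1` reaches only a limit in a functional assay on MCF7 cells (Homo sapiens) for inhibition, read by MTT assay, with a stated time of 72 h (a lower number here means a stronger inhibitor, a higher number a weaker inhibitor), namely > 40000 nM. Compound 1 `CC(C)n1ncc2c(C(=O)NCc3cn(-c4ccc(F)cc4)nn3)cccc21` likewise reaches only the limit of > 40000 nM. The step from compound 1 to compound 2, a step that the two limits leave unreadable from compound 1 to compound 2, is therefore unreadable, since both values sit at the same limit (the limit of > 40000 nM in this assay, at which 2 of the 2 values shown sit). Compound 3 `CC(C)n1ncc2c(C(=O)NCc3cn(-c4ccccc4F)nn3)cccc21` carries 2-fluorophenyl in place of 3-methylphenyl on an aromatic nitrogen. Going by the values given here, no measured step with a readable size bears on this change. The expected step of a number no higher from compound 2 to compound 3 (the limit leaves the size open) is none beyond the scatter. Compound 3 is thus estimated at 40000 nM, within a range of 10000 nM to 120000 nM, most likely again a limit.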

Compound 3, half-maximal inhibitory concentration: > 40000 nM
Compound 3: only a limit was reported; the forecaster's own chance of this, stated with the estimate: 75%; the middle value sits exactly at the limit.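

Going by these compounds alone, compound 1, compound 2 and compound 3 each give only a limit in this assay, so no step among them can be read: the limit of > 40000 nM in this assay, at which 3 of the 3 values shown sit. The compounds shown leave open how 2-fluorophenyl, 3-methylphenyl and 4-fluorophenyl compare in this assay.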